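Cytotoxicity notes on the series, compounds 1 to 4

The source may hold more compounds than are shown below. What is called first, only, known or untested is meant among the compounds shown, and "the series" means these compounds.

Measured in an ADME assay on HepG2 cells (Homo sapiens) for cytotoxicity, read by CellTiter-Glo and ATP content, with a stated time of 72 h; a higher number here means that more compound is needed for the effect, a lower number that less compound is needed:
compound 1 `CN(Cc1cccc(F)c1)C(=O)CNC(=O)c1ccc(S(C)(=O)=O)c([N+](=O)[O-])c1` gives > 27000 nM.
compound 2 `CS(=O)(=O)c1ccc(C(=O)NCCC(=O)N2CCc3ccccc32)cc1[N+](=O)[O-]` gives > 27000 nM.
compound 3 `CC(C)N(C(=O)C1CCN(C(=O)c2ccc(S(C)(=O)=O)c([N+](=O)[O-])c2)CC1)C(C)C` gives > 27000 nM.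

For compound 3 the entry in this assay is a limit of the assay, not a number. The entries for compound 1 and compound 2 are limits as well. So compound 3 stands where all three shown values stand: the limit of > 27000 nM in this assay, at which 3 of the 3 values shown sit. Within the data shown here, no step between measured compounds can be computed, since no pair of them gives two numbers to compare; none of the three can be called more or less cytotoxic than another.

Compound 4 `CC1Cc2ccccc2N1C(=O)C1CCN(C(=O)c2ccc(S(C)(=O)=O)c([N+](=O)[O-])c2)CC1` is the next compound to be measured in this assay. It differs from compound 3 in one place: 2-methyl-2,3-dihydro-1H-indol-1-yl in place of diisopropylamino on a carbonyl carbon.

With every value shown sitting at the limit, the expectation for the step from compound 3 to compound 4 in this assay is none beyond the scatter, with the result most likely again a limit rather than a number. The expected step is a step that the limit leaves unreadable from compound 3 to compound 4. Compound 4 is therefore estimated at 30000 nM, with a range from 15000 nM to 100000 nM.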

Compound 4, half-maximal effective concentration: > 27000 nM
Compound 4: only a limit was reported; the forecaster's own chance of this, stated with the estimate: 80%; the middle value is on the limit's open side.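

In this assay compound 4 gives > 27000 nM, a limit and not a number. The entry for compound 3 is a limit too, so no step between compound 3 and compound 4 can be read: the limit of > 27000 nM in this assay, at which 4 of the 4 values shown sit.

The compounds shown leave open where the cytotoxicity of any of them lies, and whether 2-methyl-2,3-dihydro-1H-indol-1-yl in place of diisopropylamino changes it at all.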